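Azetidine sulfonamide series: amide-side aryl swap toward indazole

The source may hold more compounds than are shown below. What is called first, only, known or untested is meant among the compounds shown, and "the series" means these compounds.

Measured so far in a functional assay on MCF7 cells (Homo sapiens) for antiproliferative activity, with a stated time of 72 h; on this read-out higher numbers stand for an effect only at larger amounts of compound and lower numbers for an effect already at smaller amounts:
- compound 1 `O=C(NO)c1ccc(N(Cc2ccc(C3CCOCC3)cc2)C(=O)[C@H]2CCN2S(=O)(=O)c2c(F)c(F)c(F)c(F)c2F)cc1`: > 10000 nM
- compound 2 `CNC(=O)c1ccc(N(Cc2ccc(C3CCCCC3)cn2)C(=O)[C@H]2CCN2S(=O)(=O)c2c(F)c(F)c(F)c(F)c2F)cc1O`: 3800 nM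
- compound 3 `CNC(=O)c1ccc(N(Cc2cnc(C3CCCCC3)cn2)C(=O)[C@H]2CCN2S(=O)(=O)c2c(F)c(F)c(F)c(F)c2F)cc1O`: "not determined" (no result reported)

Compound 1 gives only a limit of the assay, > 10000 nM, which is the limit of > 10000 nM in this assay, at which 1 of the 3 values shown sits. Compound 3 was not measured in this assay. For the measured compounds named here, compound 2 therefore stands as the only compound with a number in this assay, at 3800 nM, and no step between measured compounds can be read.

Compound 4 `O=C([C@H]1CCN1S(=O)(=O)c1c(F)c(F)c(F)c(F)c1F)N(Cc1ccc(C2CCCCC2)cn1)c1cc2[nH]ncc2cc1F` differs from compound 2 by 5-fluoro-1H-indazol-6-yl in place of 3-hydroxy-4-(methylcarbamoyl)phenyl on an amide-type nitrogen. With nothing measured on either side of this change, the step is expected to be small, at most toward lower values and not clearly beyond the scatter; compound 4 is estimated at 2500 nM, between 600 nM and 10000 nM, an expected 1.5-fold lower number from compound 2 to compound 4 (0.18 log units; within the scatter).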

Compound 4, half-maximal effective concentration: 4800 nM
Beside the measured number, compound 4's estimate is 1.9-fold (0.28 log units) below it; low and high end bracket the measured number.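

For the compounds shown here, the swap of 3-hydroxy-4-(methylcarbamoyl)phenyl for 5-fluoro-1H-indazol-6-yl on the amide-type nitrogen gives the first readable step in this assay (a 1.3-fold higher number from compound 2 to compound 4 (0.10 log units; within the scatter)). Compound 4 carries neither the hydroxy nor the methylcarbamoyl group of compound 2, yet it still reads as a number rather than a limit. No measured property in hand bears on this result.

Still open, from the compounds shown here alone, is whether a phenyl carrying only the hydroxy group or only the methylcarbamoyl group would read the same at this place. Also open, going by these compounds, is how a phenyl carrying a carboxylic acid or an amine there would read.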